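A few compounds are considered here, and "the series" means these few. Any claim that something is new, unique, unknown or untested is made for them only; others in the source may bear on it.

Compound 1 `CC1(C)[C@@H]2CC[C@@]1([C@@H](O)CN1CCN(c3ccc(Cl)cc3)CC1)C(=O)C2`: 8600 nM
Compound 2 `CC1(C)[C@@H]2CC[C@@]1([C@@H](O)CN1CCCCC1)C(=O)C2`: 143000 nM
Compound 3 `CC1(C)[C@@H]2CC[C@@]1([C@H](O)CN1CCN(c3ccc(Cl)cc3)CC1)C(=O)C2`: 9200 nM

Of the compounds shown here, three sharing one core have been measured in an ADME assay on HEK-293T cells (Homo sapiens) for cytotoxicity, read by MTT assay, with a stated time of 72 h; a higher number here means a weaker inhibitor, a lower number a stronger inhibitor. Compound 1 gives 8600 nM, the lowest of the three numbers. Compound 3 gives 9200 nM, and the step of a 1.1-fold higher number from compound 1 to compound 3 (0.03 log units; within the scatter) lies within the scatter, which is unsurprising because of the fact that compounds 1 and 3 differ only in the configuration as drawn. Compound 2, which carries no aromatic ring on the ring nitrogen, gives 143000 nM, far from compound 1 and beyond the scatter.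

The compound now in question is compound 4 `CC1(C)[C@@H]2CC[C@@]1([C@@H](O)CN1CCN(c3ccccc3F)CC1)C(=O)C2`. It differs from compound 1 in one place: 2-fluorophenyl in place of 4-chlorophenyl on an amine nitrogen in a ring. Going by the values given here, only one measured step exists, that from compound 1 to compound 3, and it concerns configuration alone, so it says little about exchanging one halogenated phenyl for another. The values of compound 1 and compound 2 show that the group on the amine nitrogen in the ring can shift the number greatly, but compound 4 keeps a phenyl ring there, so a shift of that size is not anticipated. On this basis the step from compound 1 to compound 4 is expected to be small, a 1.4-fold higher number from compound 1 to compound 4 (0.14 log units; within the scatter), most likely within the scatter and if anything toward a slightly higher number. Compound 4 is therefore estimated at 12000 nM, with a range from 5000 nM to 30000 nM.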

Compound 4, half-maximal inhibitory concentration: 129000 nM
Estimate against measurement, compound 4: 11-fold (1.03 log units) below; measured number above the stated range.
By their numbers in this assay, from the lowest: compounds 1 and 3 (each within the scatter of the next); then compounds 4 and 2 (each within the scatter of the next).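

In this assay the exchange of 4-chlorophenyl for 2-fluorophenyl on an amine nitrogen in a ring gives a 15-fold higher number from compound 1 to compound 4 (1.18 log units; beyond the scatter), which shows that this position responds strongly even when a halogenated phenyl stays on it. The two groups are equal in heavy-atom count, and each has one six-membered aromatic ring of carbon only, so an aromatic ring at this place is not enough on its own to hold the number near the 8600 nM of compound 1 . The only fact on record about these compounds concerns configuration, and it does not bear on this exchange of groups.

The compounds shown leave open whether the step follows the halogen or its place on the phenyl: 4-fluorophenyl and 2-chlorophenyl, each of which would alter only one of the two, are not among them. Also open, from the compounds shown here alone, are where an unsubstituted phenyl on the same nitrogen would stand in this assay and whether a change of configuration would stay as small as a 1.1-fold higher number from compound 1 to compound 3 (0.03 log units; within the scatter) with 2-fluorophenyl in place.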